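The source may report more compounds than this note shows. Statements on the series, on what has been measured and on what is new or still open speak of the compounds shown alone.

Measured in a functional assay on the whole organism with Canis familiaris (Canis lupus familiaris) as the target; a higher number here means that more compound is needed for the effect, a lower number that less compound is needed:

- compound 1 `COc1ccc(-c2nc3cc[nH]cc-3n2)c(OC)c1`: 0.3 mg/kg
- compound 2 `COc1cc(OS(C)(=O)=O)ccc1-c1nc2cc[nH]cc-2n1`: 0.006 mg/kg
- compound 3 `COc1cc(C(F)(F)F)ccc1-c1nc2cc[nH]cc-2n1`: 0.009 mg/kg

Of these three numbers, compound 1 has the highest, so it needs the most compound for the effect. Both other compounds lie beyond the scatter from it, with a 50-fold lower number from compound 1 to compound 2 (1.70 log units; beyond the scatter) and a 33-fold lower number from compound 1 to compound 3 (1.52 log units; beyond the scatter). Compounds 2 and 3 cannot be told apart, with a 1.5-fold higher number from compound 2 to compound 3 (0.18 log units; within the scatter).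

Compound 4 `COc1ccc(-c2nc3cc[nH]cc-3n2)c(OCC[S+](C)[O-])c1` is still unmeasured. It keeps the core of compound 1 and carries a group of 4 heavy atoms (2 carbon, 1 oxygen, 1 sulfur; no ring) in place of a hydrogen atom, on a saturated chain carbon bound to an oxygen on an aromatic ring. Going by the values given here, both large measured steps show that this assay can respond strongly to a change on this aromatic ring, but they replace a different methoxy group from the one extended in compound 4. Among the compounds with values here, no measured compound carries the new group of 4 heavy atoms, so the data give no direct size for this step. A small shift toward a lower number is therefore expected, most likely within the scatter, and a larger fall cannot be excluded given a 50-fold lower number from compound 1 to compound 2 (1.70 log units; beyond the scatter). The expected step is a 1.5-fold lower number from compound 1 to compound 4 (0.18 log units; within the scatter). For compound 4 the estimated value is 0.2 mg/kg, with an expected range from 0.04 mg/kg to 1 mg/kg.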

Compound 4, dose for half-maximal effect: 5.2 mg/kg
Compound 4: the middle estimate sits 26-fold (1.41 log units) below what was measured; measured number outside the range, above it.
By their numbers in this assay, from the lowest: compounds 2 and 3 (each within the scatter of the next); then compound 1; then compound 4.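

In this assay, going by these compounds alone, the change on the saturated chain carbon bound to an oxygen on an aromatic ring gives the first reading at this place, and it runs the opposite way to the earlier large steps: a 17-fold higher number from compound 1 to compound 4 (1.24 log units; beyond the scatter), against a 50-fold lower number from compound 1 to compound 2 (1.70 log units; beyond the scatter) and a 33-fold lower number from compound 1 to compound 3 (1.52 log units; beyond the scatter) for the changes made elsewhere on the same ring. This place is therefore not a silent one where a group of 4 heavy atoms can simply be attached, since in this assay the step here is large and more compound is needed for the effect. Nothing available bears on why the number rises at this place.

With a single group at this place, the compounds shown leave open whether the rise belongs to this sulfur-bearing group or to any extension of the chain, a question that a plain ethyl group, a longer chain, an amine or a carboxylic acid at the same carbon would address. They also leave open whether the low numbers of compound 2 and compound 3 would hold with this group present.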